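Cytotoxicity notes on a naphthoquinone-selenide series

This account rests on a few compounds, and the source may have more. Where it says the series, first, only, none or still open, it means among the compounds named here.

Measured compounds:
compound 1 `CC1=C([Se]CC(OC(=O)[C@@H](CO)NC(=O)OC(C)(C)C)C(=O)NCCCCCC(=O)OCc2ccccc2)C(=O)c2ccccc2C1=O`: 35000 nM
compound 2 `CC1=C(SCCC(=O)OC(CC[Se]c2ccccc2)C(=O)NCCCCCC(=O)OCc2ccccc2)C(=O)c2ccccc2C1=O`: 17000 nM
compound 3 `CC1=C([Se]CC(OC(=O)[C@@H](CSSC(C)(C)C)NC(=O)C(C)(C)C)C(=O)NCCCCCC(=O)OCc2ccccc2)C(=O)c2ccccc2C1=O`: 10000 nM

In an ADME assay on HUVEC cells (Homo sapiens) for cytotoxicity, read by MTT assay, with a stated time of 24 h (on this read-out lower numbers stand for stronger inhibition and higher numbers for weaker inhibition), compound 1 gives the highest of the three numbers. Compound 2 sits nearest, with a number that is lower by a margin beyond the usual scatter, and compound 3 is furthest, its number lower by a larger margin, also beyond the scatter. Compound 4 `CC1=C([Se]CC(OC(=O)CC[Se]c2ccccc2)C(=O)NCCCCCC(=O)OCc2ccccc2)C(=O)c2ccccc2C1=O` has not been measured. Its change from compound 1 is a group of 9 heavy atoms (8 carbon, 1 selenium; one six-membered aromatic ring of carbon only) in place of a group of 11 heavy atoms (7 carbon, 1 nitrogen, 3 oxygen; no ring), on a carbonyl carbon; the group that enters is a chain of 9 heavy atoms carrying a six-membered aromatic ring of carbon only with a selenium, replacing the branched group with one defined stereocentre. For the measured compounds named here, no single-point step between measured compounds exists, so the size of the step has to be judged from what the three numbers show. Compound 2, which also carries a phenyl-selenium fragment, gives 17000 nM; on that ground a modest move to a lower number is expected for compound 4, of a size a 1.8-fold lower number from compound 1 to compound 4 (0.24 log units; within the scatter) that may still fall within the scatter. The estimate for compound 4 in this assay is 20000 nM, with a range from 8000 nM to 50000 nM.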

Compound 4, half-maximal inhibitory concentration: 3000 nM
Estimate against measurement, compound 4: 6.7-fold (0.82 log units) above, outside the stated range (below it).
By their numbers in this assay, from the lowest: compound 4; then compounds 3 and 2 (each within the scatter of the next); then compound 1.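

In this assay the exchange on a carbonyl carbon whose other neighbours are oxygen next to a carbonyl group gives a 12-fold lower number from compound 1 to compound 4 (1.07 log units; beyond the scatter) as the 2-hydroxy-1-((tert-butoxycarbonyl)amino)ethyl group leaves and the selenium-bearing chain with its six-membered aromatic ring enters. This position is therefore not indifferent in the cell read-out: a change here alone, with the shared core and the rest of the molecule unchanged, moves the number by a large step. Nothing measured here explains the size of that step.

The step replaces a whole group at once, leaving open whether the selenium, the aromatic ring or the loss of the departing group carries it. A matched chain with sulfur in place of selenium, or one ending in a plain phenyl ring without selenium, on the same carbonyl carbon would separate these parts.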